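The source may report more compounds than this note shows. Statements on the series, on what has been measured and on what is new or still open speak of the compounds shown alone.

Compound 2 `CCNc1cc(-c2ccc(NC(=O)Nc3ccc(C(F)(F)F)cc3)cc2C(F)(F)F)ccn1` stands highest of the two numbers measured in an assay on isolated protein for inhibition of serine/threonine-protein kinase PLK1 (Homo sapiens), read by radiometric assay and 33P incorporation, with a stated time of 40 min, tested at 20 uM, in the presence of a further agent that is not named here (a higher number here means more inhibition at the concentration tested (going by the name of the read-out), a lower number less inhibition), where compound 2 gives 82.9%. Compound 1 `CCNc1cc(-c2ccc(NC(=O)Nc3ccc(C)cc3)cc2C(F)(F)F)ccn1` gives 42.6% in the same test. Going by the values given here, the only measured step, a number 40.3 percentage points higher from compound 1 to compound 2 (beyond the scatter), belongs to trifluoromethyl in place of methyl on an aromatic carbon. Compound 3 `CCNc1cc(-c2ccc(NC(=O)Nc3cccc4ccccc34)cc2C(F)(F)F)ccn1` differs from compound 2 by naphthalen-1-yl in place of 4-(trifluoromethyl)phenyl on an amide-type nitrogen. Among the compounds with values here, no measured step covers this change, and the one step recorded concerns a different group, so a drop of moderate size is expected, namely a number 17.9 percentage points lower from compound 2 to compound 3 (beyond the scatter). Compound 3 is therefore expected to give 65%, with a range from 35% to 90%.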

Compound 3, a percentage reported as inhibition, at one concentration (the size of the read-out at that concentration, not a potency): 54.1%
The estimate for compound 3 lay 10.9 percentage points above the measured number, within the range that was stated.
By their numbers in this assay, from the lowest: compound 1; then compound 3; then compound 2.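

In this assay naphthalen-1-yl on the amide-type nitrogen gives a number 28.8 percentage points lower from compound 2 to compound 3 (beyond the scatter) when it replaces 4-(trifluoromethyl)phenyl, and a number 11.5 percentage points higher from compound 1 to compound 3 (beyond the scatter) when it replaces 4-methylphenyl on the same nitrogen. The same new group therefore loses inhibition against one compound and gains it against the other, so the direction of this change depends on the group that leaves. No supporting measurement bears on why this happens. On these data alone, whether a naphthalen-2-yl group or a 4-chlorophenyl group at this nitrogen would match compound 2 remains open.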